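Piperazin-1-yl in Place of 4-Fluorophenyl

The compounds below may be only part of what the source reports. "The series", "measured", "known", "first", "only" and "open" are said of these compounds alone.

Of the compounds shown here, two have been measured in a physicochemical assay for solubility; on this read-out higher numbers stand for higher solubility and lower numbers for lower solubility. Compound 1 `O=S(=O)(Nc1nccs1)c1ccc2c(c1)OCC[C@H]2c1ccc(C(F)(F)F)cc1-c1nccs1` gives 7000 nM, and compound 2 `O=S(=O)(Nc1nccs1)c1ccc2c(c1)OCC[C@@H]2c1ccc(C(F)(F)F)cc1-c1ccc(F)cc1` gives 39000 nM, the higher of the two numbers by a gap beyond the scatter. Compound 3 `O=S(=O)(Nc1nccs1)c1ccc2c(c1)OCC[C@@H]2c1ccc(C(F)(F)F)cc1N1CCNCC1` carries piperazin-1-yl in place of 4-fluorophenyl on an aromatic carbon. Within the data shown here, no measured pair shows this change, so the expectation rests on the structural change alone. The expected move is upward, a 2.6-fold higher number from compound 2 to compound 3 (0.41 log units; beyond the scatter), and its size is uncertain. For compound 3 the estimated value is 100000 nM, with an expected range of 30000 nM to 300000 nM.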

Compound 3, solubility: 288000 nM
For compound 3 the middle estimate is 2.9-fold (0.46 log units) below the measured one; the range from low to high includes it.
By their numbers in this assay, from the lowest: compound 1; then compound 2; then compound 3.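

In this assay, exchanging 4-fluorophenyl for piperazin-1-yl on this aromatic carbon, ortho to a large group and meta to a trifluoromethyl group, gives a 7.4-fold higher number from compound 2 to compound 3 (0.87 log units; beyond the scatter). Among these compounds, this is the first step read at this position, and it shows that the read-out here moves with the group on that carbon, at least for this one pair. Nothing measured here accounts for the rise. Going by these compounds, whether the ring's second nitrogen or its hydrogen-bond donor matters stays open. On these data alone, how morpholin-4-yl or an open-chain amine would stand at this carbon also remains unknown.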